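The source may hold more compounds than are shown below. What is called first, only, known or untested is meant among the compounds shown, and "the series" means these compounds.

Results in a functional assay on NCI60 cells (Homo sapiens) for antiproliferative activity, read by sulforhodamine B assay, with a stated time of 48 h; on this read-out higher numbers stand for weaker inhibition of growth and lower numbers for stronger inhibition of growth:

- Compound 1 `COc1cc(C2CC(=O)Nc3c(-c4ccccc4)nsc32)c(OC)c(O)c1O`: "not determined" (no result reported)
- Compound 2 `COc1ccc(-c2nsc3c2NC(=O)CC3c2cccc(OC)c2)cc1`: 1550 nM

Among the measured compounds shown here, compound 2 is the only compound with a number so far, as no result was reported for compound 1. Its standing therefore cannot be judged against any other measured compound. The next compound, compound 3 `COc1ccc(-c2nsc3c2NC(=O)CC3c2cccc(F)c2)cc1`, differs from compound 2 in one place: fluoro in place of methoxy on an aromatic carbon. This puts fluoro in place of methoxy on an aromatic carbon, turning the 3-methoxyphenyl into 3-fluorophenyl. For the measured compounds named here, no measured pair shows what such a change does in this assay, so the expectation rests only on compound 2 at 1550 nM and on the change itself. The estimated step is a 1.5-fold higher number from compound 2 to compound 3 (0.19 log units; within the scatter), a modest one towards weaker inhibition of growth that may not clear the usual scatter. For compound 3 the expected value is 2400 nM, with an estimated range from 800 nM to 7500 nM.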

Compound 3, concentration for 50% growth inhibition: 4900 nM
Estimate against measurement, compound 3: 2.0-fold (0.31 log units) below, and the stated range covers the measured number.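

On an aromatic carbon of a six-membered aromatic ring of carbon only, meta to a large group, fluoro in place of methoxy in this assay gives a 3.2-fold higher number from compound 2 to compound 3 (0.50 log units; beyond the scatter) and thus weaker inhibition of growth for the 3-fluorophenyl than for the 3-methoxyphenyl. This first measured step shows that the group at this place can move the read-out beyond the usual scatter, and that methoxy is the better of the two groups shown here. No measurement at hand accounts for this difference.

On these data alone, whether the step reflects the loss of methoxy or the arrival of fluoro stays open, and a plain hydrogen, a chloro group or an amine at this place would help to separate the two. Other positions on this ring and on the second aromatic ring also remain open.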